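A few compounds are considered here, and "the series" means these few. Any claim that something is new, unique, unknown or untested is made for them only; others in the source may bear on it.

Measured so far in a functional assay on the whole organism (strain Swiss) with Mus musculus as the target, in the maximal electroshock model, with a stated time of 0.5 h, at a dose of 300 mg/kg by the intraperitoneal route; on this read-out higher numbers stand for a stronger effect at the one dose given and lower numbers for a weaker effect:
Compound 1 `CC(C(=O)N1CCN(c2ccccc2F)CC1)N1C(=O)CCC1=O` gives 50%.
Compound 2 `CCC(C(=O)N1CCN(c2ccccc2F)CC1)N1C(=O)CCC1=O` gives 100%.
Compound 3 `CC(C(=O)N1CCN(c2ccccc2C(F)(F)F)CC1)N1C(=O)CCC1=O` gives 100%.

Compound 1 stands lowest of the three numbers; its nearest neighbour is compound 2 and its furthest is compound 3, both at the same distance from it and both beyond the scatter. Two steps start from compound 1: a number 50 percentage points higher from compound 1 to compound 2 (beyond the scatter), and a number 50 percentage points higher from compound 1 to compound 3 (beyond the scatter). Each departure from compound 1 measured so far has therefore carried the read-out to the top of the range.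

Compound 4 `Cc1cccc(N2CCN(C(=O)C(C)N3C(=O)CCC3=O)CC2)c1` differs from compound 1 by 3-methylphenyl in place of 2-fluorophenyl on an amine nitrogen in a ring. Neither measured step is this change. The step to compound 3 alters the same aromatic ring, but only by trifluoromethyl in place of fluoro on an aromatic carbon, whereas here the whole aryl group is exchanged; the step to compound 2 lies on the saturated chain and does not bear on it. What remains is that compound 1 gives the lowest number in the set and that both changes made to it so far raised the read-out by a large step in this assay. A rise is accordingly expected, with low confidence: a number 25 percentage points higher from compound 1 to compound 4 (beyond the scatter). Compound 4 is estimated at 75%, within 40% to 100%.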

Compound 4, a percentage reported as activity, at one dose (the size of the read-out at that dose, not a potency): 50%
Compound 4: the middle estimate sits 25 percentage points above what was measured, within the range that was stated.
By their numbers in this assay, from the lowest: compounds 1 and 4 (each within the scatter of the next); then compounds 2 and 3 (each within the scatter of the next).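

In this assay, 3-methylphenyl in place of 2-fluorophenyl on the amine nitrogen in a ring gives no change at the digits printed from compound 1 to compound 4 (within the scatter), the first departure from compound 1 that leaves the read-out where it stood. A change to the aryl group on this nitrogen therefore does not by itself raise the number, although trifluoromethyl in place of fluoro on the aromatic ring gives a number 50 percentage points higher from compound 1 to compound 3 (beyond the scatter). Nothing at hand bears on why these two aryl changes differ.

Compound 4 alters both the substituent and its name-given ring position at once, so the contribution of each stays unresolved. Still open, from the compounds shown here alone, is how plain phenyl, or a chloro or methoxy group on the phenyl ring, would read, and whether methyl in place of hydrogen on the saturated chain would raise the number with 3-methylphenyl present.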